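This account rests on a few compounds, and the source may have more. Where it says the series, first, only, none or still open, it means among the compounds named here.

Within the data shown here, in a functional assay on MCF7 cells (Homo sapiens) for antiproliferative activity, read by MTT assay, with a stated time of 48 h (a higher number here means a weaker inhibitor, a lower number a stronger inhibitor), compound 3 `O=C(CN1CCCC1)Nc1ccc2ncnc(Nc3ccc(Cl)cc3)c2c1` gives 16000 nM, the only true number in this small set. Compound 1 `O=C(CN1CCCC1)Nc1ccc2ncnc(Nc3cccc(C(F)(F)F)c3)c2c1` gives > 100000 nM, which is a limit of the assay. Compound 2 `O=C(CN1CCCC1)Nc1ccc2ncnc(Nc3cccc(Cl)c3)c2c1` gives > 100000 nM, again a limit. Compound 4 `O=C(CN1CCCC1)Nc1ccc2ncnc(Nc3ccc(Cl)c(C(F)(F)F)c3)c2c1` differs from compound 3 by trifluoromethyl in place of hydrogen on an aromatic carbon, with trifluoromethyl in place of hydrogen on an aromatic carbon, ortho to a chloro group. The measured steps that bear on this are an at least 6.2-fold lower number from compound 1 to compound 3 (0.79 log units; beyond the scatter) and an at least 6.2-fold lower number from compound 2 to compound 3 (0.79 log units; beyond the scatter). Compound 1, which carries trifluoromethyl without the chloro group, lies on the weak side of its step, so a modest rise in the number is expected in this assay. The expected change is a 2.0-fold higher number from compound 3 to compound 4 (0.30 log units; within the scatter). Compound 4 is estimated at 32000 nM, with an expected range from 9000 nM to 110000 nM.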

Compound 4, half-maximal inhibitory concentration: > 100000 nM
Compound 4: no number, only a limit; the forecaster's own chance of this, stated with the estimate: 35%; middle value at least 3.1-fold (0.49 log units) from the limit.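

In this assay, trifluoromethyl in place of hydrogen, ortho to a chloro group, gives an at least 6.2-fold higher number from compound 3 to compound 4 (0.79 log units; beyond the scatter). The earlier steps shown here exchanged one substituted phenyl for another; here the chloro group of compound 3 stays, and it does not keep the value readable once trifluoromethyl enters.

The step from compound 1 to compound 4 cannot be read, and the full size of the loss stays hidden behind a limit: the limit of > 100000 nM in this assay, at which 3 of the 4 values shown sit. As far as these compounds go, whether fluoro, methyl or methoxy at this position would hold the value of compound 3 remains open.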